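Trifluoromethoxy in Place of Methoxy on Compound 2

The compounds below may be only part of what the source reports. "The series", "measured", "known", "first", "only" and "open" are said of these compounds alone.

Compound 1 `C=CC[C@H]1C[C@]2([C@@H](C)Cc3ccc(OC)c(OC)c3)OCOC2=CC1=O` gives 110 nM in a functional assay on M14 cells (Homo sapiens) for antiproliferative activity, with a stated time of 72 h; a lower number here means a stronger inhibitor, a higher number a weaker inhibitor.
Compound 2 `C=CC[C@H]1C[C@]2([C@@H](C)Cc3ccc(OC)cc3)OCOC2=CC1=O` gives 20 nM in this assay.
Compound 3 `C=CC[C@H]1C[C@]2([C@H](C)Cc3ccc(OC)cc3)OCOC2=CC1=O` gives 81 nM in this assay.

Among these three, compound 2 has the lowest number. Its nearest neighbour is compound 3, the step of a 4.1-fold higher number from compound 2 to compound 3 (0.61 log units; beyond the scatter), and the other is compound 1, the step of a 5.5-fold lower number from compound 1 to compound 2 (0.74 log units; beyond the scatter). The difference between compound 2 and compound 3 is accounted for by the fact that compounds 2 and 3 differ only in the configuration as drawn.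

Compound 4 `C=CC[C@H]1C[C@]2([C@@H](C)Cc3ccc(OC(F)(F)F)cc3)OCOC2=CC1=O` differs from compound 2 in one place: trifluoromethyl in place of methyl on an oxygen on an aromatic ring. Neither measured step touches that oxygen. For the measured compounds named here, one step removes a whole methoxy from the aromatic ring, and the other flips a stereocentre on the chain; nothing so far shows what exchanging methyl for trifluoromethyl on the remaining methoxy does in this assay. The measured steps therefore give no direction for this change, and the expectation is a number close to that of compound 2, with a change no larger than the scatter or a modest one either way. Compound 4 is estimated at 35 nM, between 10 nM and 130 nM. This estimate means a step of a 1.8-fold higher number from compound 2 to compound 4 (0.24 log units; within the scatter), expected to stay within the ordinary scatter.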

Compound 4, half-maximal inhibitory concentration: > 20000 nM
Compound 4: no number, only a limit; the forecaster's own chance of this, stated with the estimate: 2%; middle value at least 570-fold (2.75 log units) away from the limit.
By their numbers in this assay, from the lowest: compound 2; then compounds 3 and 1 (each within the scatter of the next). At a limit, above all of these: compound 4.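

In this assay, exchanging methyl for trifluoromethyl on the oxygen of the remaining methoxy gives an at least 1000-fold higher number from compound 2 to compound 4 (3.00 log units; beyond the scatter), a far larger step than the removal of a methoxy in a 5.5-fold lower number from compound 1 to compound 2 (0.74 log units; beyond the scatter) or the change of configuration in a 4.1-fold higher number from compound 2 to compound 3 (0.61 log units; beyond the scatter). The reading for compound 4 is a limit of the assay and not a number: the limit of > 20000 nM in this assay, at which 1 of the 4 values shown sits.

For the compounds shown here, neither earlier step touched this oxygen, so only this pair shows that the group on it matters, and that a single exchange there can move the number much further than anything seen among compounds 1, 2 and 3.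

The compounds shown do not reveal why this exchange has so large an effect, since no property of either group was measured alongside the assay. Going by these compounds, it also remains open whether the loss is tied to trifluoromethyl alone or extends to other groups at this place, such as a hydroxyl, an ethoxy or a single fluorine atom in place of the methoxy.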